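Nitro Substitution on Two Anilide Cores in a Cytotoxicity Assay

The compounds below may be only part of what the source reports. "The series", "measured", "known", "first", "only" and "open" are said of these compounds alone.

Measured compounds:
compound 1, `COc1cc(NC(=O)c2ccc(Cl)cc2)ccc1NS(=O)(=O)C(F)(F)F`, > 250000 nM
compound 2, `COc1cc(NC(=O)c2ccc(Cl)c([N+](=O)[O-])c2)ccc1NS(=O)(=O)C(F)(F)F`, > 250000 nM
compound 3, `CS(=O)(=O)Nc1ccc(NC(=O)c2ccc(Cl)cc2)cc1F`, 216000 nM

In an ADME assay on HEK293 cells (Homo sapiens) for cytotoxicity, read by MTT assay, with a stated time of 48 h (a lower number here means a stronger inhibitor, a higher number a weaker inhibitor), compound 1 gives > 250000 nM, which is a limit of the assay rather than a number. Made from compound 1 by nitro in place of hydrogen on an aromatic carbon, compound 2 gives > 250000 nM in this assay, again a limit. The step that the two limits leave unreadable from compound 1 to compound 2 therefore cannot be read, as the limit of > 250000 nM in this assay, at which 2 of the 3 values shown sit, shows. Compound 3 differs from compound 1 in its core in a way not broken down here. In this assay, within the data shown here, compound 3 gives 216000 nM, the only number among the three.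

Compound 4, `CS(=O)(=O)Nc1ccc(NC(=O)c2ccc(Cl)c([N+](=O)[O-])c2)cc1F`, is not yet measured. It arises from compound 3 by nitro in place of hydrogen on an aromatic carbon, the same change that leads from compound 1 to compound 2. Since that earlier step is unreadable, the expectation for compound 4 rests mainly on the weak activity of compound 3 at 216000 nM, and it is estimated that the step of a 1.2-fold higher number from compound 3 to compound 4 (0.06 log units; within the scatter) will be small. Compound 4 is expected to give about 250000 nM in this assay, between 130000 nM and 500000 nM, with a fair chance of only a limit.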

Compound 4, half-maximal inhibitory concentration: 23100 nM
The estimate for compound 4 lay 11-fold (1.03 log units) above the measured number; the whole stated range lies above it.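

On the core of compound 3, nitro in place of hydrogen on an aromatic carbon, ortho to a chloro group, gives a 9.4-fold lower number from compound 3 to compound 4 (0.97 log units; beyond the scatter) in this assay. The same change on the core of compound 1 leads to compound 2, but that step cannot be read, since compound 1 and compound 2 each give only a limit of the assay: the limit of > 250000 nM in this assay, at which 2 of the 4 values shown sit. The lower number is therefore seen on one core only, and the results neither confirm nor contradict that the change carries over to the core of compound 1, so a single readable step establishes no pattern across cores.

On these data alone, it remains open whether the lower number is specific to nitro or would also appear with another group at the same place, such as an amine, a nitrile or a carboxylic acid. As far as these compounds go, it is also open whether the step depends on the chloro group, or which of the differences between the two cores bears on the outcome.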